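Benzyl-aryl variation on the shared core, step to compound 3

The compounds below may be only part of what the source reports. "The series", "measured", "known", "first", "only" and "open" are said of these compounds alone.

Compound 1 `CCCn1c(=O)c2nc(-c3cnn(Cc4cccc(Cl)c4)c3)[nH]c2n(CCC)c1=O` gives 18 nM in an in vitro assay on HEK293 cells for displacement of a labelled ligand from adenosine receptor A2b (Homo sapiens); a lower number here means a stronger inhibitor, a higher number a weaker inhibitor. Within the data shown here, compound 2 `CCCn1c(=O)c2nc(-c3cnn(Cc4c(F)cc(F)cc4F)c3)[nH]c2n(CCC)c1=O` gives 650 nM in this assay, the highest of the two numbers known so far; its nearest neighbour is compound 1, with the change a 36-fold higher number from compound 1 to compound 2 (1.56 log units; beyond the scatter). Compound 3 `CCCn1c(=O)c2nc(-c3cnn(Cc4ccccc4OC)c3)[nH]c2n(CCC)c1=O` differs from compound 2 by 2-methoxyphenyl in place of 2,4,6-trifluorophenyl on a saturated chain carbon bound to an aromatic nitrogen. Among the measured compounds shown here, the only measured step that touches this part of the molecule is the one from compound 1 to compound 2, which was large, so an exchange of the aryl group here can move the number a long way. Compound 2 sits at the weak end; a single substituent on the ring, as in compound 1, went with a much lower number. The expected step of a 6.5-fold lower number from compound 2 to compound 3 (0.81 log units; beyond the scatter) therefore points toward a lower number, but the size is uncertain. For compound 3 the estimate is 100 nM, expected to lie between 20 nM and 600 nM.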

Compound 3, inhibition constant: 37 nM
Compound 3: middle estimate off by 2.7-fold (0.43 log units), on the high side; low and high end bracket the measured number.
By their numbers in this assay, from the lowest: compound 1; then compound 3; then compound 2.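

In this assay, the second large step at this place, an 18-fold lower number from compound 2 to compound 3 (1.24 log units; beyond the scatter), shows that the number can also fall sharply on leaving the 2,4,6-trifluorophenyl group, and that a second singly substituted ring, 2-methoxyphenyl, lies far below compound 2. The step between the two singly substituted rings, a 2.1-fold higher number from compound 1 to compound 3 (0.31 log units; beyond the scatter), is modest though beyond the scatter, so among the three compounds, compound 2 stands apart while compound 1 and compound 3 lie much closer together. No measurement shown here bears on the reason for these differences.

Whether the high number of compound 2 follows the count of fluorines or their placement remains open, as the compounds shown do not separate the two. Also open, going by these compounds, is how an unsubstituted phenyl ring, or a ring carrying an amine or a carboxylic acid, would compare at this place.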